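Azido for hydroxy on the series' hydroxymethyl arm

The source may hold more compounds than are shown below. What is called first, only, known or untested is meant among the compounds shown, and "the series" means these compounds.

Of the compounds shown here, two have been measured in a functional assay on P388 cells (Mus musculus) for antiproliferative activity, with a stated time of 72 h; a lower number here means that less compound is needed, a higher number that more compound is needed for the effect. Compound 1 (`Cc1cn([C@@H]2O[C@H](CO)[C@@H](CF)[C@H]2O)c(=O)[nH]c1=O`) gives > 100 uM, which is a limit of the assay. Compound 2 (`Cc1cn([C@@H]2O[C@H](CO)[C@@H](CO)[C@H]2O)c(=O)[nH]c1=O`) gives > 100 uM, also a limit of the assay. Compound 2 therefore stands without a numerical value, and the evidence so far is the limit of > 100 uM in this assay, at which 2 of the 2 values shown sit.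

The next structure is compound 3 (`Cc1cn([C@@H]2O[C@H](CO)[C@@H](CN=[N+]=[N-])[C@H]2O)c(=O)[nH]c1=O`), with azido in place of hydroxy on a saturated chain carbon bound to a saturated ring carbon. The same difference can be read as hydroxymethyl to azidomethyl.

Going by the values given here, only one measured step bears on this change, since it falls at the same place: a step that the two limits leave unreadable from compound 1 to compound 2. That step has no readable size, so it offers no magnitude or direction to carry over. No step beyond the scatter is therefore expected in this assay, and a further limit is the likeliest report. The expected outcome is a step that the limit leaves unreadable from compound 2 to compound 3. Compound 3 is estimated at 150 uM, with an expected range of 60 uM to 300 uM.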

Compound 3, concentration for half-maximal effect: > 100 uM
Compound 3: no number, only a limit; the forecaster's own chance of this, stated with the estimate: 85%; the middle value is on the limit's open side.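

In this assay, going by these compounds alone, compound 3 gives > 100 uM as a limit of the assay, so no step among compound 1, compound 2 and compound 3 can be read. The compounds shown leave open whether fluoro, hydroxy or azido at this place gives any numerical value in this assay at all. The series stands here: the limit of > 100 uM in this assay, at which 3 of the 3 values shown sit.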